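Fluoro on the Phenyl Ring: Cytotoxicity Expected Near Compound 2

A few compounds are considered here, and "the series" means these few. Any claim that something is new, unique, unknown or untested is made for them only; others in the source may bear on it.

Measured so far:
Compound 1 `O[C@@H]1Cc2cc(Br)ccc2N[C@H](c2ccccc2)C1`: 42100 nM
Compound 2 `O[C@@H]1Cc2cc(Cl)ccc2N[C@H](c2ccccc2)C1`: 191000 nM

In an ADME assay on Vero cells (Chlorocebus sabaeus) for cytotoxicity, read by MTT assay, with a stated time of 72 h (on this read-out higher numbers stand for lower toxicity in this test and lower numbers for higher toxicity in this test), compound 2 gives the higher of the two numbers, with compound 1 behind it by a 4.5-fold higher number from compound 1 to compound 2 (0.66 log units; beyond the scatter). Compound 3 `O[C@@H]1Cc2cc(Cl)ccc2N[C@H](c2ccccc2F)C1` differs from compound 2 by fluoro in place of hydrogen on an aromatic carbon. For the measured compounds named here, the only measured step concerns chloro in place of bromo on the core and does not touch the phenyl ring, so nothing here bears directly on this change. Compound 3 is therefore expected to stay close to compound 2, with a step of a 1.2-fold lower number from compound 2 to compound 3 (0.08 log units; within the scatter), giving an estimate of 160000 nM within 60000 nM to 400000 nM.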

Compound 3, half-maximal cytotoxic concentration: 182000 nM
Beside the measured number, compound 3's estimate is 1.1-fold (0.06 log units) below it; the range from low to high includes it.
By their numbers in this assay, from the lowest: compound 1; then compounds 3 and 2 (each within the scatter of the next).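

In this assay fluoro in place of hydrogen on an aromatic carbon, ortho to a large group, gives a 1.0-fold lower number from compound 2 to compound 3 (0.02 log units; within the scatter) and so leaves the two compounds indistinguishable in this test. For the compounds shown here, this is the first reading from the phenyl ring, since the earlier step concerned only the halogen on the core. No supporting data are available to explain this result. Whether this holds for larger groups stays open: the compounds shown say nothing about an amine, a carboxylic acid or a methoxy group at this place.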